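Extending the amide chain from butyl to hexyl

A few compounds are considered here, and "the series" means these few. Any claim that something is new, unique, unknown or untested is made for them only; others in the source may bear on it.

Three compounds share one core and were tested in a functional assay on the whole organism (strain Wistar) for inhibition, with Rattus norvegicus as the target, read by paw edema, with stated times of 60 min and 2 h, at a dose of 100 mg/kg by the oral route; on this read-out higher numbers stand for more inhibition at the one dose given (going by the name of the read-out) and lower numbers for less inhibition. Compound 1 `COc1cc2c(cc1OC)C(CC(N)=O)CC2` gives 31%; compound 2 `CNC(=O)CC1CCc2cc(OC)c(OC)cc21` gives 30%; compound 3 `CCCCNC(=O)CC1CCc2cc(OC)c(OC)cc21` gives 24%. Compound 3 has the smallest number of the three, but the steps of a number 7 percentage points lower from compound 1 to compound 3 (within the scatter) and a number 6 percentage points lower from compound 2 to compound 3 (within the scatter) both stay within the scatter, as does a number 1 percentage points lower from compound 1 to compound 2 (within the scatter), so nothing separates these three on this read-out.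

Compound 4 `CCCCCCNC(=O)CC1CCc2cc(OC)c(OC)cc21` is the unmeasured one. Its change from compound 3 is ethyl in place of hydrogen on a saturated chain carbon, four bonds along the chain from an amide-type nitrogen. Among the measured compounds shown here, the steps that bear on it are those that lengthen the same chain: hydrogen to methyl, hydrogen to butyl, and methyl to butyl, none of which moved the number beyond the scatter. A further lengthening is therefore expected to give a step of a number 3 percentage points lower from compound 3 to compound 4 (within the scatter), that is, no change beyond the scatter. For compound 4 in this assay the expected value is 21%, with a range from 8% to 34%.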

Compound 4, a percentage reported as inhibition, in the whole organism at one dose (the size of the read-out at that dose, not a potency): 41.5%
The estimate for compound 4 lay 20.5 percentage points below the measured number; the measured number lies above the stated range.
By their numbers in this assay, from the lowest: compounds 3, 2 and 1 (each within the scatter of the next); then compound 4.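

In this assay, among the compounds shown here, hexyl on the amide nitrogen is the first chain in this set to move the number beyond the scatter, with a number 17.5 percentage points higher from compound 3 to compound 4 (beyond the scatter), a number 11.5 percentage points higher from compound 2 to compound 4 (beyond the scatter) and a number 10.5 percentage points higher from compound 1 to compound 4 (beyond the scatter). The position therefore does respond to chain length, although the methyl chain of compound 2 and the butyl chain of compound 3 showed no such response, and the added ethyl on the butyl chain makes the difference here. No measurement offered here accounts for this rise.

The compounds shown leave open whether a pentyl chain already gives the higher number and whether a longer chain, such as octyl or decyl, raises it further or loses it. They also leave open whether a ring at the end of the chain, such as phenyl or cyclohexyl, can stand in for hexyl.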